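The source may report more compounds than this note shows. Statements on the series, on what has been measured and on what is new or still open speak of the compounds shown alone.

Measured compounds:
- Compound 1, `Cc1ccc(S(=O)(=O)NCc2ccc(CNC(=O)c3ccc([N+](=O)[O-])cc3)cc2)cc1`: in an assay on MDA-MB-231 cells for binding affinity to C-X-C chemokine receptor type 4 (Homo sapiens), read by immunofluorescence and microscopy, with stated times of 10 min and 30 min (a lower number here means that less compound is needed, a higher number that more compound is needed for the effect), compound 1 gives 10 nM.
- Compound 2, `Cc1ccc(S(=O)(=O)NCc2ccc(CNC(=O)c3ccc(F)cc3)cc2)cc1`: in this assay compound 2 gives 1 nM.

Among the compounds with values here, compound 2 has the lowest of the two numbers; its nearest neighbour is compound 1, and the only measured step, a 10-fold lower number from compound 1 to compound 2 (1.00 log units; beyond the scatter), sets the two apart by more than the scatter. Compound 3, `COc1ccc(C(=O)NCc2ccc(CNS(=O)(=O)c3ccc(C)cc3)cc2)cc1`, is built from compound 2 by one change: methoxy in place of fluoro on an aromatic carbon. Within the data shown here, no measured pair shows a methoxy group, so the single known step, from nitro to fluoro, bears on it only loosely: it shows that the group at this place can move the number well beyond the scatter, but not in which direction a methoxy group would act. For compound 3 in this assay a small rise is therefore expected, a 2.0-fold higher number from compound 2 to compound 3 (0.30 log units; within the scatter), that may well stay within the scatter. Compound 3 is estimated at 2 nM, with a range from 0.5 nM to 10 nM.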

Compound 3, effective concentration (reported as EC, without a stated level of effect): 100 nM
Estimate against measurement, compound 3: 50-fold (1.70 log units) below; measured number outside the range, above it.
By their numbers in this assay, from the lowest: compound 2; then compound 1; then compound 3.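

Replacing fluoro with methoxy at this place on the ring gives a 100-fold higher number from compound 2 to compound 3 (2.00 log units; beyond the scatter) in this assay and is the largest step seen so far. Methoxy in place of nitro gives a 10-fold higher number from compound 1 to compound 3 (1.00 log units; beyond the scatter) and so the three groups now fall into a clear order, with fluoro needing the least compound, nitro more and methoxy the most. No measurement shown here gives a reason for this order.

The compounds shown leave open where other groups at this place, such as an amine, a carboxylic acid or a chlorine atom, would fall in that order. They also leave open whether a longer chain ending in the same oxygen link, such as ethoxy, would raise the number further than methoxy does.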